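A few compounds are considered here, and "the series" means these few. Any claim that something is new, unique, unknown or untested is made for them only; others in the source may bear on it.

Among the compounds with values here, compound 1 `CCC(=O)Nc1cc2ccc(O[C@@H]3OC(C)(C)[C@H](OC)[C@@H](O)[C@H]3O)c(C)c2oc1=O` gives 643000 nM in a functional assay on SK-BR-3 cells (Homo sapiens) for antiproliferative activity (on this read-out higher numbers stand for weaker inhibition and lower numbers for stronger inhibition), the highest of the two numbers so far. Within the data shown here, compound 2 `CCCCC(=O)Nc1cc2ccc(O[C@@H]3OC(C)(C)[C@H](OC)[C@@H](O)[C@H]3O)c(C)c2oc1=O` gives 118000 nM in this assay; the only measured step is a 5.4-fold lower number from compound 1 to compound 2 (0.74 log units; beyond the scatter). Compound 3 `CO[C@@H]1[C@@H](O)[C@@H](O)[C@H](Oc2ccc3cc(NC(=O)C4CCC4)c(=O)oc3c2C)OC1(C)C` remains to be measured. It differs from compound 1 by cyclobutyl in place of ethyl on a carbonyl carbon. The step of a 5.4-fold lower number from compound 1 to compound 2 (0.74 log units; beyond the scatter) is the one that bears on it: there too carbon was added at the acyl group on the amide-type nitrogen, so a lower number is expected here as well, though the ring may not behave like the open chain. Compound 3 is therefore expected near 220000 nM, within 80000 nM to 600000 nM, which would mean a 2.9-fold lower number from compound 1 to compound 3 (0.47 log units; beyond the scatter).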

Compound 3, half-maximal inhibitory concentration: 220000 nM
Beside the measured number, compound 3's estimate shows no gap at the digits printed; low and high end bracket the measured number.
By their numbers in this assay, from the lowest: compounds 2 and 3 (each within the scatter of the next); then compound 1.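

Cyclobutyl on the carbonyl carbon also moves the number down, with a 2.9-fold lower number from compound 1 to compound 3 (0.47 log units; beyond the scatter), so this position accepts a ring as well as an open chain in place of ethyl. Ring and open chain are not told apart here, with a 1.9-fold higher number from compound 2 to compound 3 (0.27 log units; within the scatter). No available evidence accounts for either step.

Going by these compounds, whether the trend continues with larger groups remains open, since all three numbers stay high. A longer chain, a cyclohexyl ring or an acyl group carrying an amine would test how far this position extends.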